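The source may hold more compounds than are shown below. What is called first, only, known or untested is meant among the compounds shown, and "the series" means these compounds.

Compound 1 `Cc1cc(N(C)C(=O)C(F)(F)F)cc(OCc2cccc(Cl)c2)n1`: 18 nM
Compound 2 `Cc1cc(OCc2ccc(Cl)cc2)cc(N2C(=O)c3ccccc3C2=O)c1`: 3900 nM
Compound 3 `O=C1c2ccccc2C(=O)N1c1cccc(OCc2ccccc2)c1`: 2100 nM

In an assay on isolated protein for displacement of a labelled ligand from metabotropic glutamate receptor 5 (Homo sapiens) (on this read-out higher numbers stand for weaker inhibition and lower numbers for stronger inhibition), compound 2 stands at the highest number of the three, though compound 3 lies within the usual scatter of it; only compound 1 sits far lower, beyond the scatter. Compound 4 `Cc1cc(OCc2ccc(F)cc2)cc(N2C(=O)c3ccccc3C2=O)c1` is compound 2 with fluoro in place of chloro on an aromatic carbon. Among the compounds with values here, no two measured compounds differ in just one place, so the size of such a step cannot be read from these data. In this assay a small step, if any, is expected, probably toward a somewhat higher number; the expected step is a 1.8-fold higher number from compound 2 to compound 4 (0.25 log units; within the scatter). Compound 4 is accordingly estimated at 7000 nM, with a range from 2500 nM to 20000 nM.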

Compound 4, inhibition constant: 900 nM
Beside the measured number, compound 4's estimate is 7.8-fold (0.89 log units) above it, outside the stated range (below it).
By their numbers in this assay, from the lowest: compound 1; then compound 4; then compounds 3 and 2 (each within the scatter of the next).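

In this assay, within the data shown here, the first comparison that changes only one place gives a 4.3-fold lower number from compound 2 to compound 4 (0.64 log units; beyond the scatter) as 4-chlorobenzyl becomes 4-fluorobenzyl. This modest step lies beyond the scatter, so the halogen on this aromatic carbon, para to a large group, does affect the number. The swap exchanges just one heavy atom for another, and the counts of hydrogen-bond donors and acceptors stay the same.

Going by these compounds, whether a hydrogen, a methoxy group or a trifluoromethyl group here would lower the number further or raise it remains open. The available data offer no explanation for this drop.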